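The compounds below may be only part of what the source reports. "The series", "measured", "known", "first", "only" and "open" are said of these compounds alone.

In a functional assay on CHO-K1 cells for antagonist activity at transient receptor potential cation channel subfamily V member 1 (Homo sapiens), read by FLIPR (a lower number here means a stronger inhibitor, a higher number a weaker inhibitor), compound 3 `CC(C(=O)NCc1ccc(C(F)(F)F)nc1N1CCC(c2ccccc2)CC1)c1ccc(NS(C)(=O)=O)c(F)c1` gives 0.6 nM, a number lying between those of compound 1 `CC(C(=O)NCc1ccc(C(F)(F)F)nc1N(C)c1ccccc1)c1ccc(NS(C)(=O)=O)c(F)c1` with 0.9 nM and compound 2 `CC(C(=O)NCc1ccc(C(F)(F)F)nc1N1CCC(C)(C)CC1)c1ccc(NS(C)(=O)=O)c(F)c1` with 0.3 nM, though the steps of a 1.5-fold lower number from compound 1 to compound 3 (0.18 log units; within the scatter) and a 2.0-fold higher number from compound 2 to compound 3 (0.30 log units; within the scatter) both stay within the scatter. Compound 4 `CC(=O)OC1CCN(c2nc(C(F)(F)F)ccc2CNC(=O)C(C)c2ccc(NS(C)(=O)=O)c(F)c2)CC1` carries the change (acetoxy in place of phenyl on a saturated ring carbon). For the measured compounds named here, the only measured step at that saturated ring carbon, a 2.0-fold higher number from compound 2 to compound 3 (0.30 log units; within the scatter), was within the scatter, and the larger swaps of the whole amine, a 3.0-fold lower number from compound 1 to compound 2 (0.48 log units; beyond the scatter) and a 1.5-fold lower number from compound 1 to compound 3 (0.18 log units; within the scatter), were modest at most. Compound 4 is therefore expected to show no step beyond the scatter, a 1.3-fold higher number from compound 3 to compound 4 (0.12 log units; within the scatter). The estimate for compound 4 in this assay is 0.8 nM, within a range of 0.3 nM to 2.5 nM.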

Compound 4, inhibition constant: 4 nM
Beside the measured number, compound 4's estimate is 5.0-fold (0.70 log units) below it; measured number outside the range, above it.
By their numbers in this assay, from the lowest: compounds 2, 3 and 1 (each within the scatter of the next, the first and the last beyond it); then compound 4.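

For the compounds shown here, the saturated ring carbon proves sensitive in this assay: acetoxy in place of phenyl gives a 6.7-fold higher number from compound 3 to compound 4 (0.82 log units; beyond the scatter), the first step at this carbon beyond the scatter. The 4-acetoxypiperidin-1-yl group also stands apart from the other two amines, with a 13-fold higher number from compound 2 to compound 4 (1.12 log units; beyond the scatter) and a 4.4-fold higher number from compound 1 to compound 4 (0.65 log units; beyond the scatter), which puts compound 4 beyond the scatter of all three earlier compounds. No measurement at hand accounts for this result. The compounds shown leave open how a hydroxy, methoxy or acetylamino group on that carbon would compare with acetoxy and phenyl.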